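Changing the Group on the Ring Nitrogen: Compound 3

This account rests on a few compounds, and the source may have more. Where it says the series, first, only, none or still open, it means among the compounds named here.

Compound 2 `COc1cc(C2=NN(S(=O)(=O)c3ccc(C)cc3)C(c3ccc(Cl)cc3)C2)ccc1O` sits at the lower of the two numbers in an ADME assay on HepG2 cells (Homo sapiens) for cytotoxicity, read by MTT assay, with a stated time of 24 h, tested at 5 uM (on this read-out lower numbers stand for a stronger effect and higher numbers for a weaker effect at the one concentration tested), where compound 2 gives 79.6%; compound 1 `COc1cc(C2=NN(C(=O)c3ccccc3)C(c3ccc(Cl)cc3)C2)ccc1O` gives 86.3%, and the difference is a number 6.7 percentage points lower from compound 1 to compound 2 (within the scatter). Compound 3 `COc1cc(C2=NN(C(=S)Nc3ccccc3)C(c3ccc(Cl)cc3)C2)ccc1O` differs from compound 2 in this way: a group of 9 heavy atoms (7 carbon, 1 nitrogen, 1 sulfur; one six-membered aromatic ring of carbon only) in place of a group of 10 heavy atoms (7 carbon, 2 oxygen, 1 sulfur; one six-membered aromatic ring of carbon only), on an amine nitrogen in a ring. Among the compounds with values here, no measured step swaps these two groups; the only comparison available, benzoyl to (4-methylphenyl)sulfonyl, stayed within the scatter, so no shift beyond the scatter is expected in this assay. Compound 3 is therefore estimated at 80%, between 65% and 95%, an expected step of a number 0.4 percentage points higher from compound 2 to compound 3 (within the scatter).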

Compound 3, a percentage reported as activity, at one concentration (the size of the read-out at that concentration, not a potency): 88.2%
Compound 3: middle estimate off by 8.2 percentage points, on the low side, and the stated range covers the measured number.
By their numbers in this assay, from the lowest: compounds 2, 1 and 3 (each within the scatter of the next).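

With a third kind of group on the amine nitrogen in a ring, one carrying a hydrogen-bond donor, this assay shows a number 8.6 percentage points higher from compound 2 to compound 3 (within the scatter) and a number 1.9 percentage points higher from compound 1 to compound 3 (within the scatter). All three groups at this position therefore lie within the scatter of one another, even though the entering group differs from both others in its atoms and its hydrogen-bond donor count. No evidence on the cause accompanies these numbers.

Going by these compounds, whether a carboxylic acid or a short chain ending in an amine at this position would shift the number beyond the scatter remains open.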